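The source may hold more compounds than are shown below. What is called first, only, known or untested is meant among the compounds shown, and "the series" means these compounds.

Working notes on the series. In an ADME assay on microsomes (Homo sapiens) for metabolic stability (on this read-out lower numbers stand for slow clearance and higher numbers for fast clearance), compound 1 (`N#Cc1ccc(CC(=O)c2cc3n(n2)CCCC3)nc1`) gives 46 mL.min-1.g-1 as its number. Compound 2 (`N#Cc1ccc(NC(=O)c2cc3n(n2)CCCC3)nc1`) gives 83 mL.min-1.g-1 and compound 3 (`O=C(Nc1ccc(F)cn1)c1cc2n(n1)CCCC2`) gives 31 mL.min-1.g-1 on the same scale. The number for compound 1 lies within the scatter of each of the other two, so it cannot be separated from either. Within the data shown here, those two do separate: the one measured step is a 2.7-fold lower number from compound 2 to compound 3 (0.43 log units; beyond the scatter) and it is modest but beyond the scatter, with fluoro in place of cyano on an aromatic carbon.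

Compound 4 (`N#Cc1ccc(CC(=O)c2nn3c(c2Cl)CCCC3)nc1`) differs from compound 1 by chloro in place of hydrogen on an aromatic carbon with chloro in place of hydrogen on an aromatic carbon of the five-membered aromatic ring. Among the measured compounds shown here, no measured step covers chloro at this place, and the fluoro for cyano step lies elsewhere in the structure, so it serves only as a rough guide to size. In this assay the estimated step is a 1.1-fold lower number from compound 1 to compound 4 (0.04 log units; within the scatter) and nothing beyond the scatter is expected, with no direction favoured. Compound 4 is estimated at 42 mL.min-1.g-1 (expected range 19 mL.min-1.g-1 to 90 mL.min-1.g-1).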

Compound 4, intrinsic clearance in microsomes: 79 mL.min-1.g-1
The estimate for compound 4 lay 1.9-fold (0.27 log units) below the measured number; measured number inside the range.
By their numbers in this assay, from the lowest: compounds 3, 1, 4 and 2 (each within the scatter of the next, the first and the last beyond it).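

In this assay, among these compounds, this is the first reading of any change on the five-membered aromatic ring: chloro in place of hydrogen gives a 1.7-fold higher number from compound 1 to compound 4 (0.23 log units; within the scatter). The added chlorine therefore leaves compound 4 inseparable from compound 1, and this single step fixes no direction for chloro at this place. No data given here bear on the reason for this result.

Open, on these data alone, is whether another group at this place, such as methyl, methoxy or an amine, would give a step beyond the scatter. Also open, as far as these compounds go, is whether chloro at this place gives a step of similar size on the amides compound 2 and compound 3.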